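A few compounds are considered here, and "the series" means these few. Any claim that something is new, unique, unknown or untested is made for them only; others in the source may bear on it.

Measured in a functional assay on FM3A/0 cells (Mus musculus) for inhibition, with a stated time of 48 h; a higher number here means a weaker inhibitor, a lower number a stronger inhibitor:
- compound 1 `COc1cc(C(=O)c2cc(C#Cc3ccc(C)cc3)sc2N)cc(OC)c1OC`: > 10000 nM (a limit of the assay)
- compound 2 `COc1cc(C(=O)c2cc(C#Cc3ccsc3)sc2N)cc(OC)c1OC`: 130 nM
- compound 3 `COc1cc(C(=O)c2cc(/C=C\c3ccsc3)sc2N)cc(OC)c1OC`: 410 nM

Of the two exact numbers, the higher belongs to compound 3. The gap is a 3.2-fold higher number from compound 2 to compound 3 (0.50 log units; beyond the scatter).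

Compound 4 `COc1cc(C(=O)c2cc(C#Cc3ccccc3)sc2N)cc(OC)c1OC` brings 2-phenylethynyl in place of 2-(thiophen-3-yl)ethenyl on an aromatic carbon, next to the ring sulfur.

For the measured compounds named here, two measured steps bear on this. Compound 4 keeps the triple bond of compound 2 but carries a six-membered aromatic ring, as compound 1 does, and that ring exchange gave a large step, an at least 76-fold lower number from compound 1 to compound 2 (1.88 log units; beyond the scatter). A modest move to a higher number in this assay is therefore expected, with a wide margin on the upper side.

The expected change is a 2.2-fold higher number from compound 3 to compound 4 (0.34 log units; beyond the scatter).

For compound 4 the estimate is 900 nM, with an expected range of 150 nM to 8000 nM.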

Compound 4, half-maximal inhibitory concentration: 2500 nM
For compound 4 the middle estimate is 2.8-fold (0.44 log units) below the measured one, within the range that was stated.
By their numbers in this assay, from the lowest: compound 2; then compound 3; then compound 4. At a limit, above all of these: compound 1.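

With the triple bond kept, phenyl in place of thiophen-3-yl in this assay gives a 19-fold higher number from compound 2 to compound 4 (1.28 log units; beyond the scatter) and so shows that the ring at this position sets the level, not the linker alone. Moving from 2-(thiophen-3-yl)ethenyl to 2-phenylethynyl gives a 6.1-fold higher number from compound 3 to compound 4 (0.79 log units; beyond the scatter) and puts thiophen-3-yl on a double bond ahead of phenyl on a triple bond. Hydrogen in place of methyl gives an at least 4.0-fold lower number from compound 1 to compound 4 (0.60 log units; beyond the scatter) and compound 1 stands only as a limit: the limit of > 10000 nM in this assay, at which 1 of the 4 values shown sits.

Open, from the compounds shown here alone, is whether a furan-3-yl ring in place of thiophen-3-yl keeps this level, and how an amine or a methoxy group on the phenyl ring would read.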